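The source may report more compounds than this note shows. Statements on the series, on what has been measured and on what is new or still open speak of the compounds shown alone.

Compound 1 `CCCCCCCCCCCCCCCCCCNC(=O)[C@H]1CSC(c2cccc(O)c2)N1` gives 1700 nM; compound 2 `CCCCCCCCCCCCCCCCCCNC(=O)[C@H]1CSC(c2ccc([N+](=O)[O-])cc2)N1` gives 8400 nM; compound 3 `CCCCCCCCCCCCCCCCCCNC(=O)[C@H]1CSC(c2ccc(C#N)cc2)N1` gives 5900 nM.

In a functional assay on LNCaP cells (Prostate gland, Homo sapiens) for antiproliferative activity, read by sulforhodamine B assay (a lower number here means a stronger inhibitor, a higher number a weaker inhibitor), compound 3 stands second highest of the three numbers: the step of a 1.4-fold lower number from compound 2 to compound 3 (0.15 log units; within the scatter) lies within the scatter, whereas a 3.5-fold higher number from compound 1 to compound 3 (0.54 log units; beyond the scatter) lies beyond it. Compound 4 `CCCCCCCCCCCCCCCCCCNC(=O)[C@H]1CSC(c2ccc(C)cc2)N1` is the next compound, differing from compound 3 by methyl in place of cyano on an aromatic carbon. Among the compounds with values here, no measured step exchanges a cyano for a methyl. Within the data shown here, the only exchange at this aromatic carbon, a 1.4-fold lower number from compound 2 to compound 3 (0.15 log units; within the scatter), was within the scatter, while the changes of the whole aryl group, a 4.9-fold higher number from compound 1 to compound 2 (0.69 log units; beyond the scatter) and a 3.5-fold higher number from compound 1 to compound 3 (0.54 log units; beyond the scatter), were modest. A step no larger than the scatter is therefore expected, a 1.2-fold lower number from compound 3 to compound 4 (0.07 log units; within the scatter), and compound 4 is estimated at 5000 nM, within 2000 nM to 12000 nM.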

Compound 4, half-maximal inhibitory concentration: 1900 nM
The estimate for compound 4 lay 2.6-fold (0.42 log units) above the measured number, and the stated range ends above it.
By their numbers in this assay, from the lowest: compounds 1 and 4 (each within the scatter of the next); then compounds 3 and 2 (each within the scatter of the next).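

With this assay as the measure, exchange at this aromatic carbon, para to a large group, now proves able to move the number: a 3.1-fold lower number from compound 3 to compound 4 (0.49 log units; beyond the scatter) and a 4.4-fold lower number from compound 2 to compound 4 (0.65 log units; beyond the scatter) are both beyond the scatter, unlike the earlier exchange of nitro for cyano. Meanwhile, a 1.1-fold higher number from compound 1 to compound 4 (0.05 log units; within the scatter) is within the scatter, so 4-methylphenyl and 3-hydroxyphenyl cannot be told apart here. No available evidence bears on why methyl separates from cyano and nitro. From the compounds shown here alone, whether an amine or a methoxy group at this carbon would group with methyl or with cyano stays open, as does the effect of a shorter chain in place of the long one.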